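The source may hold more compounds than are shown below. What is called first, only, known or untested is meant among the compounds shown, and "the series" means these compounds.

Series on the shared core:
compound 1 `NC(=O)c1cn(Cc2ccccc2)c2ncnc(N)c12`: 75000 nM
compound 2 `Cc1cccc(Cn2cc(C(N)=O)c3c(N)ncnc32)c1`: > 100000 nM
compound 3 `COc1ccc(Cn2cc(C(N)=O)c3c(N)ncnc32)cc1`: 47000 nM

In a functional assay on KB cells (Homo sapiens) for cytotoxicity (on this read-out higher numbers stand for weaker inhibition and lower numbers for stronger inhibition), compound 1 gives 75000 nM, the highest of the two numbers present; compound 3 gives 47000 nM, the nearest value, within scatter of compound 1. For compound 2 this assay reports only a limit, > 100000 nM, not a number (the limit of > 100000 nM in this assay, at which 1 of the 3 values shown sits). The two measured steps, an at least 1.3-fold higher number from compound 1 to compound 2 (0.12 log units; that floor lies within the scatter) and a 1.6-fold lower number from compound 1 to compound 3 (0.20 log units; within the scatter), both change a substituent on the aromatic carbon of the benzyl group and both lie within scatter.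

Compound 4 `N#Cc1cn(Cc2ccccc2)c2ncnc(N)c12` differs from compound 1 by cyano in place of carbamoyl on an aromatic carbon. For the measured compounds named here, no measured step touches this position or this group, so nothing in the data supports a step beyond the scatter in this assay in either direction; the expectation rests on compound 1 alone. Compound 4 is therefore expected near 75000 nM, range 20000 nM to 300000 nM, which is no change at the digits printed from compound 1 to compound 4 (within the scatter) as the expected step.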

Compound 4, half-maximal inhibitory concentration: > 100000 nM
Compound 4: no number, only a limit (the forecaster's own chance of this, stated with the estimate: 35%); middle value at least 1.3-fold (0.12 log units) away from the limit.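

In this assay, with compounds 2 and 3 changing only the benzyl group, cyano in place of carbamoyl on the aromatic carbon gives an at least 1.3-fold higher number from compound 1 to compound 4 (0.12 log units; that floor lies within the scatter). Compound 4 gives > 100000 nM, which is a limit and not a number, so how far this step runs cannot be read. The same limit now bounds more of the series: the limit of > 100000 nM in this assay, at which 2 of the 4 values shown sit.

The compounds shown carry only carbamoyl and cyano at this position, so the outcome with a carboxylic acid, an amine or a longer chain there remains open. On these data alone, whether any change at this position gives a step beyond the scatter also remains open.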